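The source may hold more compounds than are shown below. What is called first, only, known or untested is meant among the compounds shown, and "the series" means these compounds.

Measured so far in a physicochemical assay for lipophilicity, read by NMR; a higher number here means a more lipophilic compound, a lower number a more polar compound:

- compound 1, `CCC(F)CCO`, gives 0.75
- compound 2, `CCC(F)(F)CCO`, gives 0.92
- compound 3, `OCCC(F)(F)C(F)F`, gives 0.66

Three short fluorinated alcohols, all within the usual scatter of one another in this assay. Compound 2 and compound 1 differ by hydrogen in place of fluoro on a saturated chain carbon bound to a fluorine atom and two saturated chain carbons; the step is a number 0.17 log units lower from compound 2 to compound 1 (within the scatter). Compound 2 and compound 3 differ in their cores by difluoromethyl in place of ethyl on a saturated chain carbon bound to two fluorine atoms and a saturated chain carbon, and the step is a number 0.26 log units lower from compound 2 to compound 3 (within the scatter). Compound 3 sits closest to compound 1 and furthest from compound 2, but neither gap exceeds the scatter, so no ordering among the three is claimed.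

Compound 4, `OCCC(F)C(F)F`, has not yet been measured in this assay. It differs from compound 3 by hydrogen in place of fluoro on a saturated chain carbon bound to a fluorine atom and two saturated chain carbons. This is the same change as the one between compound 2 and compound 1, made on a core that differs as described above, and it occurs twice among the compounds shown. Going by the values given here, the only precedent for such a change is a number 0.17 log units lower from compound 2 to compound 1 (within the scatter), a small downward shift within the scatter, and the expectation rests on that single precedent applied to compound 3 at 0.66. An estimated step of a number 0.17 log units lower from compound 3 to compound 4 (within the scatter) is therefore expected for compound 4, of the same sign and size as the earlier one. On that basis compound 4 is expected to give about 0.49 in this assay, with a plausible range from 0.25 to 0.75, which would leave it within the scatter of compound 3 and compound 1.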

Compound 4, partition coefficient: 0.29
For compound 4 the middle estimate is 0.20 log units above the measured one; the measured number falls inside the stated range.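

In this assay, hydrogen in place of fluoro on a saturated chain carbon bound to a fluorine atom and two saturated chain carbons gives a number 0.37 log units lower from compound 3 to compound 4 (beyond the scatter) on the core shared by that pair, so here the change has an effect that can be read. Going by these compounds alone, the same change gives a number 0.17 log units lower from compound 2 to compound 1 (within the scatter) on the other core, so only one of the two pairs stands clear of the scatter, and these two pairs neither fix a step size that can be carried from one core to another nor show that the two cores truly respond differently. Nothing available bears on what sets the size of either step.

The compounds shown leave open whether the change would give a step that can be read on further cores, since a series of two pairs cannot separate a real dependence on the core from repeat-measurement scatter. Also open, going by these compounds, is how the same change would read on a longer chain, or on a core carrying an amine or a carboxylic acid in place of the alcohol.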